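The source may hold more compounds than are shown below. What is called first, only, known or untested is meant among the compounds shown, and "the series" means these compounds.

Measured compounds:
- compound 1 `COc1cccc(/C=C/C(=O)c2c(OC)cc(OC)cc2OC)c1`: 8700 nM
- compound 2 `COc1cc(OC)c(C(=O)/C=C/c2ccc(Cl)cc2)c(OC)c1`: 8200 nM
- compound 3 `COc1cc(O)c(C(=O)/C=C/c2ccccc2SC)c(OC)c1`: > 20000 nM

Three compounds sharing one core were tested in a functional assay on MDA-MB-231 cells (Homo sapiens) for cytotoxicity, with a stated time of 48 h; on this read-out higher numbers stand for weaker inhibition and lower numbers for stronger inhibition. Compound 1 gives 8700 nM in this assay. Compound 2 gives 8200 nM, and the step of a 1.1-fold lower number from compound 1 to compound 2 (0.03 log units; within the scatter) is too small to be told apart from repeat measurement noise, so the two numbers sit together. Compound 3, which carries a free hydroxyl on the core and a methylthio group on the other ring, reached only a limit, > 20000 nM; that is the limit of > 20000 nM in this assay, at which 1 of the 3 values shown sits, not a number.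

Compound 4 `COc1cc(OC)c(C(=O)/C=C/c2ccccc2OC)c(OC)c1` is not yet measured. It differs from compound 1 in one place: 2-methoxyphenyl in place of 3-methoxyphenyl on a double-bonded chain carbon bound to a double-bonded chain carbon. Within the data shown here, the only measured step that touches the same position is the change from compound 1 to compound 2, in which a different substituted phenyl at that position left the number essentially unchanged, a 1.1-fold lower number from compound 1 to compound 2 (0.03 log units; within the scatter). On that basis the expected step of a 1.0-fold lower number from compound 1 to compound 4 (0.01 log units; within the scatter) is small, with no direction beyond the scatter. Compound 4 is therefore estimated at 8500 nM, within a range of 3500 nM to 20000 nM, in this assay.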

Compound 4, half-maximal inhibitory concentration: 13000 nM
For compound 4 the middle estimate is 1.5-fold (0.18 log units) below the measured one, within the range that was stated.
By their numbers in this assay, from the lowest: compounds 2, 1 and 4 (each within the scatter of the next). At a limit, above all of these: compound 3.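

The two groups hold the same atoms, so this change tests only where the methoxy group is attached to the phenyl ring: in this assay, 2-methoxyphenyl in place of 3-methoxyphenyl gives a 1.5-fold higher number from compound 1 to compound 4 (0.17 log units; within the scatter) and thus shows that this placement of the methoxy group cannot be told apart from the earlier one. Against a different substituent, 2-methoxyphenyl in place of 4-chlorophenyl gives a 1.6-fold higher number from compound 2 to compound 4 (0.20 log units; within the scatter), so three differently substituted phenyl groups on a double-bonded chain carbon bound to a double-bonded chain carbon now sit together, where earlier there were only two. No measurement shown here bears on the reason for this flat picture.

Among these compounds, every group at this place so far is a substituted phenyl ring, so it stays open how the shared core behaves with a longer chain there, or with a phenyl ring carrying an amine or a carboxylic acid. Whether any group at this place can give a step beyond the scatter also stays open, since every step at this place shown here lies within it.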